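Adding a Second Methoxy Group: What to Expect

The source may hold more compounds than are shown below. What is called first, only, known or untested is meant among the compounds shown, and "the series" means these compounds.

Measured so far:
Compound 1, `COc1ccc(-c2cc(/C=C/C(=O)c3ccc(N)cc3)[nH]n2)cc1`: -41%
Compound 2, `COc1ccc(C(=O)/C=C/c2cc(-c3cc(OC)c(OC)c(OC)c3)n[nH]2)cc1`: -16%

Of the compounds shown here, two have been tested in a functional assay on OVCAR-8 cells (Homo sapiens) for cytotoxicity, read by sulforhodamine B assay, with a stated time of 48 h, tested at 100 uM; a lower number here means a stronger effect, a higher number a weaker effect of the compound at the concentration tested. Compound 1 gives -41% there, the lowest number of the two and thus the stronger effect. For the measured compounds named here, compound 2, in the same assay, gives -16%, a number higher than that of compound 1 by a gap that lies beyond the usual scatter; no step between these two has been worked out, so only the two values themselves speak.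

The next compound, compound 3, `COc1ccc(-c2cc(/C=C/C(=O)c3ccc(N)cc3)[nH]n2)cc1OC`, keeps everything of compound 1 and changes a single place: methoxy in place of hydrogen on an aromatic carbon. Going by the values given here, no measured pair shows what such a change does on this core, so the expectation rests on compound 1 alone. A small group entering at an aromatic carbon is expected to move the number only a little, and in this assay the step from compound 1 to compound 3 is expected to be a number 6 percentage points higher from compound 1 to compound 3 (within the scatter), a shift not clearly beyond the scatter. Compound 3 is therefore estimated at -35%, with a likely range from -60% to -10%.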

Compound 3, a percentage reported as activity, at one concentration (the size of the read-out at that concentration, not a potency): -86%
Compound 3: middle estimate off by 51 percentage points, on the high side; the whole stated range lies above it.
By their numbers in this assay, from the lowest: compound 3; then compound 1; then compound 2.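

In this assay, methoxy in place of hydrogen on an aromatic carbon, ortho to a methoxy group and meta to a large group, gives a number 45 percentage points lower from compound 1 to compound 3 (beyond the scatter), so this position on the ring of compound 1 is far from silent and even a small added group can change the read-out strongly here. The two earlier compounds differ in more than one place, so they could not tie a shift to any single position; this step ties a large move towards the stronger effect to one defined change. Nothing available explains why so small a change has so large an effect.

From the compounds shown here alone, what a hydroxyl group, a fluorine atom or an ethoxy group would do on this same aromatic carbon stays open, so it cannot yet be said whether the step belongs to methoxy in particular or to almost any group placed there. Also open, going by these compounds, is whether a methoxy group on another carbon of this ring would give a similar step, and whether the gain carries over to lower concentrations, since a reading at one concentration is not a potency.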